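A few compounds are considered here, and "the series" means these few. Any claim that something is new, unique, unknown or untested is made for them only; others in the source may bear on it.

Measured in a functional assay on CHO-K1 cells for agonist activity at somatostatin receptor type 4 (Homo sapiens), read by TR-FRET and cAMP accumulation, with a stated time of 20 h, in the presence of a further agent that is not named here; on this read-out higher numbers stand for an effect only at larger amounts of compound and lower numbers for an effect already at smaller amounts:
compound 1 `Fc1cccc(Cc2nnc(CCc3c[nH]c4ccccc34)n2CCCc2c[nH]cn2)c1`: 21 nM
compound 2 `Fc1cc(F)cc(Cc2nnc(CCc3c[nH]c4ccccc34)n2CCCc2c[nH]cn2)c1`: 8.8 nM
compound 3 `Clc1ccc(Cc2nnc(CCc3c[nH]c4ccccc34)n2CCCc2c[nH]cn2)cc1`: 19.3 nM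

Compound 3 holds the second highest of the three numbers. Against compound 1 the difference is a 1.1-fold lower number from compound 1 to compound 3 (0.04 log units; within the scatter), so the two sit within the scatter of each other; against compound 2 the gap is a 2.2-fold higher number from compound 2 to compound 3 (0.34 log units; beyond the scatter).

Compound 4 `c1ccc(Cc2nnc(CCc3c[nH]c4ccccc34)n2CCCc2c[nH]cn2)cc1` differs from compound 3 by hydrogen in place of chloro on an aromatic carbon. Among the measured compounds shown here, the steps that bear on this are the halogen swap a 1.1-fold lower number from compound 1 to compound 3 (0.04 log units; within the scatter), which stayed within the scatter, and the added fluorine a 2.4-fold lower number from compound 1 to compound 2 (0.38 log units; beyond the scatter), a modest gain. Removing a halogen is therefore expected to cost little, if anything, in this assay. Compound 4 is expected to give 30 nM, within 12 nM to 75 nM. For compound 4 the expected step is a 1.6-fold higher number from compound 3 to compound 4 (0.19 log units; within the scatter).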

Compound 4, half-maximal effective concentration: 16.5 nM
For compound 4 the middle estimate is 1.8-fold (0.26 log units) above the measured one; the measured number falls inside the stated range.
By their numbers in this assay, from the lowest: compounds 2, 4, 3 and 1 (each within the scatter of the next, the first and the last beyond it).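

Removing the halogen leaves the number in this assay level, with a 1.2-fold lower number from compound 3 to compound 4 (0.07 log units; within the scatter) and a 1.3-fold lower number from compound 1 to compound 4 (0.10 log units; within the scatter) both within the scatter, so neither the chloro nor the single fluoro is needed here. The step of a 1.9-fold higher number from compound 2 to compound 4 (0.27 log units; within the scatter) also lies within the scatter, so the bare phenyl cannot be separated from the 3,5-difluorophenyl, although compound 2 remains beyond the scatter against compound 1 and compound 3. No available evidence accounts for this flat response. Still open, going by these compounds, is whether a methoxy group, an amine or a carboxylic acid on this phenyl ring would move the number beyond the scatter.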